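The source may report more compounds than this note shows. Statements on the series, on what has been measured and on what is new or still open speak of the compounds shown alone.

Of the compounds shown here, three sharing one core have been tested in a functional assay on SMMC-7721 cells (Homo sapiens) for antiproliferative activity, read by CCK-8 assay, with a stated time of 48 h; on this read-out lower numbers stand for stronger inhibition and higher numbers for weaker inhibition. Compound 1 `CCSc1n[nH]c(-n2[se]c3ccccc3c2=O)n1` gives 10000 nM, compound 2 `CCCCCCSc1n[nH]c(-n2[se]c3ccccc3c2=O)n1` gives 22400 nM, and compound 3 `Cc1cccc(CSc2n[nH]c(-n3[se]c4ccccc4c3=O)n2)c1` gives 9040 nM. Compound 3 shows the lowest number of the three, though its gap to compound 1 lies within the scatter. Compound 4 `CCCCCSc1n[nH]c(-n2[se]c3ccccc3c2=O)n1` differs from compound 3 by butyl in place of 3-methylphenyl on a saturated chain carbon bound to a sulfur. Among the measured compounds shown here, two measured steps bear on this change: a 2.5-fold lower number from compound 2 to compound 3 (0.39 log units; beyond the scatter), of which the present change is nearly the reverse, and a 2.2-fold higher number from compound 1 to compound 2 (0.35 log units; beyond the scatter), which also lengthens a chain on the same sulfur. Compound 4 is therefore expected to give a modestly higher number, estimated at 16000 nM with a range from 7000 nM to 35000 nM. Against compound 3, the expected step is a 1.8-fold higher number from compound 3 to compound 4 (0.25 log units; within the scatter).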

Compound 4, half-maximal inhibitory concentration: 31400 nM
Estimate against measurement, compound 4: 2.0-fold (0.29 log units) below; the range from low to high includes it.
By their numbers in this assay, from the lowest: compounds 3 and 1 (each within the scatter of the next); then compounds 2 and 4 (each within the scatter of the next).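

In this assay, replacing the 3-methylbenzyl group on the sulfur with pentyl weakens inhibition, with a 3.5-fold higher number from compound 3 to compound 4 (0.54 log units; beyond the scatter). The pentyl chain also does worse than the short chain of compound 1, with a 3.1-fold higher number from compound 1 to compound 4 (0.50 log units; beyond the scatter), whereas it cannot be told apart from the longer chain of compound 2, with a 1.4-fold higher number from compound 2 to compound 4 (0.15 log units; within the scatter). No measurement here explains why these steps occur. Going by these compounds, it remains open how an amine or a carboxylic acid would read at this place in this assay.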